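Swapping Methoxy for Methyl on the Shared Core

The compounds below may be only part of what the source reports. "The series", "measured", "known", "first", "only" and "open" are said of these compounds alone.

Compound 1 `COc1ccc2ncc(S(=O)(=O)c3ccc(C)c(Cl)c3)c(N3CCC(C)CC3)c2c1` sits in the middle of a small set of three. In an assay on isolated protein for displacement of a labelled ligand from metabotropic glutamate receptor 5 (Homo sapiens), with a stated time of 60 min, tested at 1 uM (on this read-out higher numbers stand for more inhibition at the one concentration tested (going by the name of the read-out) and lower numbers for less inhibition), compound 1 gives 85%. Compound 2 `COc1ccc2ncc(S(=O)(=O)c3ccc(Cl)c(Cl)c3)c(N3CCC(C)CC3)c2c1` gives 87% in this assay, and the move a number 2 percentage points higher from compound 1 to compound 2 (within the scatter) stays within the scatter. Compound 3 `COc1ccc2ncc(S(=O)(=O)c3cccc(Cl)c3)c(N3CCC(C)CC3)c2c1` gives -3%, so the step of a number 88 percentage points lower from compound 1 to compound 3 (beyond the scatter) and the step of a number 90 percentage points lower from compound 2 to compound 3 (beyond the scatter) are both large drops.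

Compound 4 `Cc1ccc2ncc(S(=O)(=O)c3ccc(C)c(Cl)c3)c(N3CCC(C)CC3)c2c1` differs from compound 1 at a different place from any of those steps: methyl in place of methoxy on an aromatic carbon. All three measured steps touch the ring attached to the sulfonyl group, whereas this change sits on the shared core, so none of them bears directly on it and no measured guide exists for its size or direction. The expectation therefore rests on compound 1 alone, because its value 85% is the starting point, with a wide allowance for either outcome.

Compound 4 is estimated at 78% in this assay, between 40% and 95%. The step from compound 1 to compound 4 is expected to be a number 7 percentage points lower from compound 1 to compound 4 (within the scatter), that is, no change beyond the scatter.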

Compound 4, a percentage reported as inhibition, at one concentration (the size of the read-out at that concentration, not a potency): 91%
Estimate against measurement, compound 4: 13 percentage points below; measured number inside the range.
By their numbers in this assay, from the lowest: compound 3; then compounds 1, 2 and 4 (each within the scatter of the next).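

In this assay, methyl in place of methoxy on the shared core gives a number 6 percentage points higher from compound 1 to compound 4 (within the scatter), so this swap leaves the read-out level and inhibition stays high with either group. That contrasts with the ring attached to the sulfonyl group, where replacing a single methyl with hydrogen gives a number 88 percentage points lower from compound 1 to compound 3 (beyond the scatter): the core position accepts this exchange in a way that ring position did not accept the loss of its group. Nothing available explains why the swap leaves the read-out level.

As far as these compounds go, what an amine, a carboxylic acid or a longer chain such as ethoxy would do at this place remains open. Also open, from the compounds shown here alone, is whether compound 1 and compound 4 would separate across a range of concentrations, since a single concentration gives no potency.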